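Thiourea Arm in Place of a Fluorobenzyl Group

The compounds below may be only part of what the source reports. "The series", "measured", "known", "first", "only" and "open" are said of these compounds alone.

Compound 1 `NC(=O)c1c(NC(=O)c2ccccc2Cl)sc2c1CCN(Cc1ccccc1F)C2` and compound 2 `NC(=O)c1c(NC(=O)c2ccccc2F)sc2c1CCN(Cc1cccc(Cl)c1)C2` share one core and were both tested in a functional assay on HL-60 cells (Homo sapiens) for antiproliferative activity, with a stated time of 24 h; on this read-out higher numbers stand for weaker inhibition and lower numbers for stronger inhibition. Compound 1 gives 21800 nM, and compound 2 gives 19800 nM; the two numbers lie within the usual scatter of each other, so neither compound stands apart. Compound 3 `COc1ccc(NC(=S)N2CCc3c(sc(NC(=O)c4ccccc4Cl)c3C(N)=O)C2)cc1` has not yet been measured in this assay. It differs from compound 1 in one place: a group of 11 heavy atoms (8 carbon, 1 nitrogen, 1 oxygen, 1 sulfur; one six-membered aromatic ring of carbon only) in place of a group of 8 heavy atoms (7 carbon, 1 fluorine; one six-membered aromatic ring of carbon only), on an amine nitrogen in a ring. Among the measured compounds shown here, no measured pair shows what such a change does, so no step beyond the scatter is expected in either direction. For compound 3 the estimate is 18000 nM, within 4000 nM to 70000 nM. The expected step is a 1.2-fold lower number from compound 1 to compound 3 (0.08 log units; within the scatter).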

Compound 3, half-maximal inhibitory concentration: 15700 nM
Compound 3: middle estimate off by 1.1-fold (0.06 log units), on the high side; the measured number falls inside the stated range.
By their numbers in this assay, from the lowest: compounds 3, 2 and 1 (each within the scatter of the next).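

In this assay, the thiourea arm in place of the 2-fluorobenzyl group, on an amine nitrogen in a ring, gives a 1.4-fold lower number from compound 1 to compound 3 (0.14 log units; within the scatter). This single step shows that the position takes a larger group, with a hydrogen-bond donor and acceptors that the 2-fluorobenzyl group lacks, without a shift beyond the scatter. No outside data bear on this result.

From the compounds shown here alone, whether a urea, with oxygen in place of the sulfur, or a longer chain on this nitrogen would give a step beyond the scatter stays open.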